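This account rests on a few compounds, and the source may have more. Where it says the series, first, only, none or still open, it means among the compounds named here.

Measured compounds in a functional assay for inhibition of sodium/hydrogen exchanger (Oryctolagus cuniculus); a higher number here means a weaker inhibitor, a lower number a stronger inhibitor: compound 1 `CCc1cc(C)c(C(=O)N=C(N)N)cc1S(C)(=O)=O` gives 4.8 nM; compound 2 `Cc1cc(-c2ccc(Cl)cc2)c(S(C)(=O)=O)cc1C(=O)N=C(N)N` gives 45 nM; compound 3 `Cc1cc(N2CCCC2)c(S(C)(=O)=O)cc1C(=O)N=C(N)N` gives 11 nM.

Compound 3 stands second highest of the three numbers: compound 1 is nearest, with a 2.3-fold higher number from compound 1 to compound 3 (0.36 log units; beyond the scatter), and compound 2 is furthest, with a 4.1-fold lower number from compound 2 to compound 3 (0.61 log units; beyond the scatter). Compound 4 `Cc1cn(-c2cc(C)c(C(=O)N=C(N)N)cc2S(C)(=O)=O)cn1` differs from compound 3 in one place: 4-methyl-1H-imidazol-1-yl in place of pyrrolidin-1-yl on an aromatic carbon. The step that bears most directly on this is a 4.1-fold lower number from compound 2 to compound 3 (0.61 log units; beyond the scatter), where one ring on that carbon replaced another; the step of a 9.4-fold higher number from compound 1 to compound 2 (0.97 log units; beyond the scatter) also shows that a ring on this carbon raised the number. An aromatic ring entering in place of a non-aromatic one is therefore expected to raise the number modestly, a 2.0-fold higher number from compound 3 to compound 4 (0.30 log units; within the scatter). For compound 4 the estimate is 22 nM, expected to fall within 8 nM to 60 nM.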

Compound 4, half-maximal inhibitory concentration: 28 nM
Estimate against measurement, compound 4: 1.3-fold (0.10 log units) below; the measured number falls inside the stated range.
By their numbers in this assay, from the lowest: compound 1; then compound 3; then compounds 4 and 2 (each within the scatter of the next).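

In this assay, the aromatic 4-methyl-1H-imidazol-1-yl group gives a higher number than the non-aromatic pyrrolidin-1-yl ring on the same carbon, with a 2.5-fold higher number from compound 3 to compound 4 (0.41 log units; beyond the scatter) as the step. Against the 4-chlorophenyl ring, a 1.6-fold lower number from compound 2 to compound 4 (0.21 log units; within the scatter) leaves these two aromatic groups indistinguishable here. Within the data shown here, the ethyl group of compound 1 keeps the lowest number so far, with a 5.8-fold higher number from compound 1 to compound 4 (0.77 log units; beyond the scatter) as the gap.

As far as these compounds go, whether a morpholine ring or an unsubstituted phenyl ring on this carbon would follow the same trend remains open. No measurement shown explains why these groups differ.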